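Swapping a Small Ring for an Ether Chain

The compounds below may be only part of what the source reports. "The series", "measured", "known", "first", "only" and "open" are said of these compounds alone.

Of the compounds shown here, three built on one shared core have been tested in a physicochemical assay for solubility; a lower number here means a less soluble compound, a higher number a more soluble compound. Compound 1 `COc1cc2cc(C(=O)CCC3CC[N+](C)(CC#N)CC3)sc2cc1OC` gives 2000 ug/mL. Compound 2 `C=CC[n+]1ccc(CCC(=O)c2cc3cc(OC)c(OC)cc3s2)cc1` gives 25000 ug/mL in this assay, and compound 3 `COc1cc2cc(C(=O)CCc3cc[n+](CC4CC4)cc3)sc2cc1OC` gives 15000 ug/mL. Among these three numbers compound 3 holds the second highest; its nearest neighbour is compound 2, within the usual scatter, while compound 1 stands furthest away, beyond the scatter.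

Within the data shown here, the only measured step that changes this same position is a 1.7-fold lower number from compound 2 to compound 3 (0.22 log units; within the scatter), a swap of one small group for another on the saturated chain carbon bound to the aromatic nitrogen. Compound 4 `CCOCC[n+]1ccc(CCC(=O)c2cc3cc(OC)c(OC)cc3s2)cc1` is the next such swap: it differs from compound 3 by ethoxymethyl in place of cyclopropyl on a saturated chain carbon bound to an aromatic nitrogen.

Because a 1.7-fold lower number from compound 2 to compound 3 (0.22 log units; within the scatter) stayed within the scatter, a change of this kind at this position is expected to move the number little. The step of a 1.3-fold higher number from compound 3 to compound 4 (0.12 log units; within the scatter) is therefore expected to stay within the scatter, in no clear direction. Compound 4 is estimated at 20000 ug/mL, with a range from 8000 ug/mL to 50000 ug/mL.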

Compound 4, solubility: 50000 ug/mL
For compound 4 the middle estimate is 2.5-fold (0.40 log units) below the measured one; the measured number falls inside the stated range.
By their numbers in this assay, from the lowest: compound 1; then compounds 3, 2 and 4 (each within the scatter of the next, the first and the last beyond it).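

At the saturated chain carbon bound to an aromatic nitrogen, ethoxymethyl in place of cyclopropyl gives a step in this assay that lies beyond the scatter, a 3.3-fold higher number from compound 3 to compound 4 (0.52 log units; beyond the scatter), so a swap at this position can move the number more than the earlier step suggested. The result depends on which group is replaced: ethoxymethyl in place of vinyl gives a 2.0-fold higher number from compound 2 to compound 4 (0.30 log units; within the scatter), which stays within the scatter. Nothing in the data shown explains the step.

What remains open is whether the oxygen of ethoxymethyl matters, since a butyl group, its all-carbon counterpart, is not among the compounds shown. From the compounds shown here alone, it also remains open how a longer ether chain, an amine or a carboxylic acid would behave on this same carbon.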